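Oxime and Ketone Thioethers in a Paw Edema Model

A few compounds are considered here, and "the series" means these few. Any claim that something is new, unique, unknown or untested is made for them only; others in the source may bear on it.

Compound 1 `CCn1c(SCC(=O)c2ccccc2)nnc1-c1ccc(OC)cc1` and compound 2 `CCn1c(SCC(=O)c2ccccc2)nnc1-c1ccc(OC)c(OC)c1` share a ketone side chain, while compound 3 `CCn1c(SC/C(=N/O)c2ccccc2)nnc1-c1ccc(OC)cc1` carries an oxime in its place. In a functional assay on the whole organism (strain albino) for inhibition, with Rattus norvegicus as the target, read by paw edema, with a stated time of 2 h, at a dose of 0.28 mmol/kg by the oral route (on this read-out lower numbers stand for less inhibition and higher numbers for more inhibition at the one dose given (going by the name of the read-out)), compound 1 gives 60%, compound 2 gives 55% and compound 3 gives 72%. The change from compound 2 to compound 1, (hydrogen in place of methoxy on an aromatic carbon), made a number 5 percentage points higher from compound 2 to compound 1 (within the scatter). The difference between the cores of compound 2 and compound 3 is not broken down here. Compound 4 `CCn1c(SC/C(=N/O)c2ccccc2)nnc1-c1ccccc1` has not yet been measured; it differs from compound 3 by hydrogen in place of methoxy on an aromatic carbon, the same kind of change as from compound 2 to compound 1, though here the place is para to a large group rather than ortho to a methoxy group and meta to a large group. Because the earlier step of this kind, a number 5 percentage points higher from compound 2 to compound 1 (within the scatter), stayed within the scatter, compound 4 is expected to remain close to compound 3 at 72%, with a step of a number 4 percentage points lower from compound 3 to compound 4 (within the scatter). Compound 4 is therefore estimated at 68%, between 52% and 82%.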

Compound 4, a percentage reported as inhibition, in the whole organism at one dose (the size of the read-out at that dose, not a potency): 69%
Beside the measured number, compound 4's estimate is 1 percentage points below it; measured number inside the range.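

In this assay, replacing the methoxy with hydrogen, read here as 4-methoxyphenyl to phenyl, gave a number 3 percentage points lower from compound 3 to compound 4 (within the scatter). Set beside the earlier step of the same kind on the core of compound 2, the change shows no difference between the two cores that can be told apart from the scatter: the same change on two cores in this assay, a number 5 percentage points higher (within the scatter) from compound 2 to compound 1 and a number 3 percentage points lower (within the scatter) from compound 3 to compound 4, 8 percentage points apart, within the scatter of two such steps This does not show that the methoxy never matters in this series, since it rests on only two pairs at one dose and one time point, and the place para to a large group in compound 3 is not the place where the methoxy leaves compound 2.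

The compounds shown carry only methoxy or hydrogen on this aromatic ring, so what chlorine, a hydroxyl or an amine at that place would give in this assay remains open. Also open, from the compounds shown here alone, is how a carboxylic acid in place of the oxime would read out.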